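Amide heteroaryl swaps on the indolylpyrimidine anilide series

A few compounds are considered here, and "the series" means these few. Any claim that something is new, unique, unknown or untested is made for them only; others in the source may bear on it.

Among the measured compounds shown here, compound 3 `COc1ccc(C(=O)Nc2cc(Nc3nccc(-c4cn(C)c5ccccc45)n3)c(OC)cc2N(C)C)nc1` gives 5150 nM in a functional assay on A549 cells (Homo sapiens) for antiproliferative activity, read by MTT assay, with a stated time of 72 h (a higher number here means a weaker inhibitor, a lower number a stronger inhibitor), the highest of the three numbers so far. Compound 2 `COc1cc(N(C)C)c(NC(=O)c2ccncc2OC)cc1Nc1nccc(-c2cn(C)c3ccccc23)n1` gives 3030 nM, and the step of a 1.7-fold higher number from compound 2 to compound 3 (0.23 log units; within the scatter) is within the scatter. Compound 1 `COc1cc(N(C)CCN(C)C)c(NC(=O)c2ccncn2)cc1Nc1nccc(-c2cn(C)c3ccccc23)n1` gives 2530 nM and differs from compound 3 in two places, so its value shows only that a pyrimidinyl amide can sit near the low end of this narrow spread. Compound 4 `COc1cc(N(C)C)c(NC(=O)c2ccncn2)cc1Nc1nccc(-c2cn(C)c3ccccc23)n1` carries pyrimidin-4-yl in place of 5-methoxypyridin-2-yl on a carbonyl carbon. For the measured compounds named here, the one step that bears on this, the methoxypyridyl isomer swap, was within the scatter; with compound 1 at 2530 nM as the nearest pyrimidinyl anchor, compound 4 is expected to move a 1.8-fold lower number from compound 3 to compound 4 (0.25 log units; within the scatter), no more than a small step towards a lower number. Compound 4 is estimated at 2900 nM, with a range of 1300 nM to 6500 nM.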

Compound 4, half-maximal inhibitory concentration: 5160 nM
Compound 4: the middle estimate sits 1.8-fold (0.25 log units) below what was measured; the range from low to high includes it.
By their numbers in this assay, from the lowest: compounds 1, 2, 3 and 4 (each within the scatter of the next, the first and the last beyond it).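

In this assay the carbonyl carbon tolerates the pyrimidin-4-yl group without a readable shift against the 5-methoxypyridin-2-yl group (a 1.0-fold higher number from compound 3 to compound 4 (0.00 log units; within the scatter)) or the 3-methoxypyridin-4-yl group (a 1.7-fold higher number from compound 2 to compound 4 (0.23 log units; within the scatter)), so these three amides cannot be told apart. Among the compounds shown here, the only step here beyond the scatter lies away from the amide: hydrogen in place of (dimethylamino)methyl on a saturated chain carbon gives a modest change (a 2.0-fold higher number from compound 1 to compound 4 (0.31 log units; beyond the scatter)). No supporting measurement bears on the reason for either result.

As far as these compounds go, whether an amine or a carboxylic acid on the pyrimidin-4-yl group would separate from these amides stays open. So does the effect of a longer chain on that saturated chain carbon.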